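The source may hold more compounds than are shown below. What is called first, only, known or untested is meant among the compounds shown, and "the series" means these compounds.

Measured so far:
compound 1 `CN1C[C@H](C(=O)Nc2ccc(F)cc2)[C@@H](c2ccc(/C=C/C(=O)Nc3ccccc3N)cc2)C1`, 34 mL/min/kg
compound 2 `CN1C[C@H](C(=O)Nc2ccc(C(F)(F)F)cc2)[C@@H](c2ccc(/C=C/C(=O)Nc3ccccc3N)cc2)C1`, 23 mL/min/kg
compound 3 `CN1C[C@H](C(=O)Nc2ccccc2F)[C@@H](c2ccc(/C=C/C(=O)Nc3ccccc3N)cc2)C1`, 67 mL/min/kg

In an in vitro ADME assay on microsomes from liver (Mus musculus) for pharmacokinetics, read by LC-MS, with a stated time of 10 min, tested at 1 uM (on this read-out lower numbers stand for slow clearance and higher numbers for fast clearance), compound 1 stands second highest of the three. Its nearest neighbour is compound 2, a 1.5-fold lower number from compound 1 to compound 2 (0.17 log units; within the scatter); the furthest is compound 3, a 2.0-fold higher number from compound 1 to compound 3 (0.29 log units; within the scatter). Only a 2.9-fold higher number from compound 2 to compound 3 (0.46 log units; beyond the scatter) clears the scatter, and modestly.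

Compound 4 `Cc1ccc(NC(=O)[C@H]2CN(C)C[C@@H]2c2ccc(/C=C/C(=O)Nc3ccccc3N)cc2)cn1` differs from compound 1 by 6-methylpyridin-3-yl in place of 4-fluorophenyl on an amide-type nitrogen. The most comparable measured step is the ring swap on the amide-type nitrogen, a 2.0-fold higher number from compound 1 to compound 3 (0.29 log units; within the scatter), within the scatter; the substituent swap a 1.5-fold lower number from compound 1 to compound 2 (0.17 log units; within the scatter) is also within the scatter. Among the compounds with values here, no measured step covers 6-methylpyridin-3-yl entering, so the expectation rests on these small steps: a 1.2-fold higher number from compound 1 to compound 4 (0.07 log units; within the scatter) is expected, with no direction beyond the scatter. Compound 4 is estimated at 40 mL/min/kg, range 18 mL/min/kg to 85 mL/min/kg.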

Compound 4, clearance: 57 mL/min/kg
For compound 4 the middle estimate is 1.4-fold (0.15 log units) below the measured one, and the stated range covers the measured number.
By their numbers in this assay, from the lowest: compounds 2, 1, 4 and 3 (each within the scatter of the next, the first and the last beyond it).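

In this assay, 6-methylpyridin-3-yl, the only ring here with a hetero atom on the amide-type nitrogen, stays within the scatter of both fluorinated phenyl rings (a 1.7-fold higher number from compound 1 to compound 4 (0.22 log units; within the scatter); a 1.2-fold lower number from compound 3 to compound 4 (0.07 log units; within the scatter)). It separates only from 4-(trifluoromethyl)phenyl (a 2.5-fold higher number from compound 2 to compound 4 (0.39 log units; beyond the scatter)), and modestly, so a hydrogen-bond acceptor in this ring gives no clear shift from the fluorophenyl compounds. No available evidence bears on these steps.

Open, on these data alone, is whether the methyl or the ring nitrogen carries the step, and how an amine or a carboxylic acid on this ring would read.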